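Swapping Thiophene for Furan on a Nucleoside Core

The source may report more compounds than this note shows. Statements on the series, on what has been measured and on what is new or still open speak of the compounds shown alone.

Compound 1 `COc1ncnc2c1c(-c1cccs1)cn2[C@@H]1O[C@H](CO)[C@@H](O)[C@H]1O`: 13900 nM
Compound 2 `CN(C)c1ncnc2c1c(-c1cccs1)cn2[C@@H]1O[C@H](CO)[C@@H](O)[C@H]1O`: > 20000 nM, a limit

Of the compounds shown here, two have so far been tested in a functional assay on HepG2 cells (Homo sapiens) for antiproliferative activity, read by XTT assay, with a stated time of 72 h; on this read-out higher numbers stand for weaker inhibition and lower numbers for stronger inhibition. Compound 1 gives 13900 nM, the only result reported as a number. For compound 2 the assay reports only a limit, > 20000 nM, which matches (the limit of > 20000 nM in this assay, at which 1 of the 2 values shown sits). Going by the values given here, the single measured step, an at least 1.4-fold higher number from compound 1 to compound 2 (0.15 log units; that floor lies within the scatter), concerns a change of a different group on the shared core, so it says nothing direct about the change considered here.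

Compound 3 `COc1ncnc2c1c(-c1ccco1)cn2[C@@H]1O[C@H](CO)[C@@H](O)[C@H]1O` differs from compound 1 by furan-2-yl in place of thiophen-2-yl on an aromatic carbon. Among the compounds with values here, no measured step covers this exchange, so there is no basis for expecting a shift beyond the usual scatter in either direction. The change is therefore expected to give a 1.1-fold higher number from compound 1 to compound 3 (0.03 log units; within the scatter). Compound 3 is estimated at 15000 nM, with a range from 6000 nM to 40000 nM.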

Compound 3, half-maximal inhibitory concentration: 300 nM
Estimate against measurement, compound 3: 50-fold (1.70 log units) above; the measured number lies below the stated range.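

In this assay, the exchange shown here gives a 46-fold lower number from compound 1 to compound 3 (1.67 log units; beyond the scatter), so this position is far from indifferent to the group it carries. Thiophen-2-yl and furan-2-yl match in heavy atoms, in ring size and in counted hydrogen-bond donors and acceptors, and differ only in the hetero atom, sulfur leaving and oxygen entering, so a change of one ring atom is enough for a step of this size. Going by these compounds alone, nothing measured so far accounts for why the ring with oxygen gives the lower number.

From the compounds shown here alone, it stays open whether furan-2-yl gives a similar gain with dimethylamino in place of methoxy on the shared core. The compounds shown also leave open how a phenyl ring or an ethyl chain would fare at this position.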